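Triazolopyrimidine esters: amine change on the shared core

The compounds below may be only part of what the source reports. "The series", "measured", "known", "first", "only" and "open" are said of these compounds alone.

Measured so far: compound 1 `CCOC(=O)c1cnc(NCc2ccc(F)cc2)n2nc(-c3ccco3)nc12`, 46.3 nM; compound 2 `CCOC(=O)c1cnc(NCCOC)n2nc(-c3ccco3)nc12`, 105 nM.

In an assay on CHO cells for displacement of a labelled ligand from adenosine receptor A3 (Homo sapiens) (a lower number here means a stronger inhibitor, a higher number a weaker inhibitor), compound 2 holds the highest of the two numbers; the nearest is compound 1, separated by a 2.3-fold higher number from compound 1 to compound 2 (0.36 log units; beyond the scatter). Within the data shown here, that one step is the only measured guide, and it shows that swapping the group on the amine nitrogen moves the number modestly.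

Compound 3 `CCOC(=O)c1cnc(N(C)C)n2nc(-c3ccco3)nc12` carries dimethylamino in place of (2-methoxyethyl)amino on an aromatic carbon. Among the measured compounds shown here, no measured pair covers the loss of the hydrogen-bond donor together with the shorter chain, so the step from compound 2 to compound 1 bears only indirectly, as a sign that this position is sensitive. A step at least of that size is expected, toward a higher number, with wide uncertainty.

For compound 3 in this assay the estimate is 300 nM, range 80 nM to 1200 nM, an expected change of a 2.9-fold higher number from compound 2 to compound 3 (0.46 log units; beyond the scatter).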

Compound 3, inhibition constant: 275 nM
Compound 3: the middle estimate sits 1.1-fold (0.04 log units) above what was measured; the range from low to high includes it.
By their numbers in this assay, from the lowest: compound 1; then compound 2; then compound 3.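

In this assay, dimethylamino on the aromatic carbon between two ring nitrogen atoms gives a 2.6-fold higher number from compound 2 to compound 3 (0.42 log units; beyond the scatter) and a 5.9-fold higher number from compound 1 to compound 3 (0.77 log units; beyond the scatter), so this position now spans a wider range than the first pair showed. Of the three groups, dimethylamino has the fewest heavy atoms, has no hydrogen-bond donor and gives the highest number, while (4-fluorobenzyl)amino gives the lowest. No measurement offers an explanation for these differences in binding.

The compounds shown leave the loss of the hydrogen-bond donor and the change in chain tied together in a single step, so neither can be read alone. Methylamino, which keeps the amine hydrogen on a short chain, and N-methyl-(2-methoxyethyl)amino, which removes it from the longer chain, would pull these two changes apart.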